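The source may hold more compounds than are shown below. What is called first, only, known or untested is meant among the compounds shown, and "the series" means these compounds.

Compound 1 has the structure `N#Cc1ccc(Nc2nccc(Oc3ccc(-c4ccc(C#N)cc4)cc3C(F)(F)F)n2)cc1`. In a functional assay on MT4 cells (Homo sapiens) for cytotoxicity, read by MTT assay, with a stated time of 5 days (a higher number here means that more compound is tolerated, a lower number that less compound is tolerated), compound 1 gives > 273000 nM, which is a limit of the assay and not a number. Compound 2 has the structure `N#Cc1ccc(Nc2nccc(Oc3ccc(-c4ccc(C#N)cc4)cc3Cl)n2)cc1`. In this assay compound 2 gives > 295000 nM, again a limit. Compound 3 has the structure `N#Cc1ccc(Nc2nccc(Oc3ccc(-c4ccc(C#N)cc4)c(Cl)c3)n2)cc1`. In this assay compound 3 gives 31100 nM.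

Among the compounds with values here, compound 3 therefore stands as the only compound of the three with a number in this assay; the other two sit at limits, as the lines the limit of > 273000 nM in this assay, at which 1 of the 3 values shown sits, and the limit of > 295000 nM in this assay, at which 1 of the 3 values shown sits, record. Within the data shown here, the one step among measured compounds, a step that the two limits leave unreadable from compound 1 to compound 2, cannot be read for size, since both ends are limits.

Compound 4 has the structure `COc1cc(Oc2ccnc(Nc3ccc(C#N)cc3)n2)ccc1-c1ccc(C#N)cc1`. It differs from compound 3 by methoxy in place of chloro on an aromatic carbon. Among the measured compounds shown here, no measured step puts a methoxy group in place of a chloro group, and the only measured step gives no readable size. The step from compound 3 to compound 4 is thus expected to stay within the scatter, with a 1.4-fold higher number from compound 3 to compound 4 (0.16 log units; within the scatter) as the estimated size. Compound 4 is expected to give about 45000 nM in this assay, within a range from 15000 nM to 150000 nM.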

Compound 4, half-maximal cytotoxic concentration: > 298000 nM
Compound 4: a limit, no number; the forecaster's own chance of this, stated with the estimate: 15%; middle value at least 6.6-fold (0.82 log units) away from the limit.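

In this assay, within the data shown here, the only earlier step could not be read, so this is the first step with a readable lower bound, and it sits on an aromatic carbon ortho to a 4-cyanophenyl group: with methoxy in place of chloro at this position, the series shows an at least 9.5-fold higher number from compound 3 to compound 4 (0.98 log units; beyond the scatter). The measurable value of compound 3 therefore does not carry over to this change, and a swap of a single substituent at this position is enough to move the read-out beyond the scatter. Compound 4 gives a limit of the assay and not a number: the limit of > 298000 nM in this assay, at which 1 of the 4 values shown sits.

The step has only a lower bound, so its true size stays open, and the compounds shown offer no measured property that would explain it. Also open, on these data alone, is whether an amine, a hydroxy group or a longer chain such as ethoxy at the same position would behave as methoxy does, and whether methoxy would have the same effect on a core carrying a different group elsewhere.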